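The source may hold more compounds than are shown below. What is called first, only, known or untested is meant among the compounds shown, and "the series" means these compounds.

In a functional assay on PC-3 cells (Homo sapiens) for inhibition, read by sulforhodamine B assay, with a stated time of 72 h (a lower number here means a stronger inhibitor, a higher number a weaker inhibitor), the measured compounds read:

Compound 1 `CC1CCN(C(=O)c2c(N)sc(-c3ccc(Cl)cc3)c2-c2ccc(Cl)cc2)CC1`: 5750 nM
Compound 2 `Nc1sc(-c2ccc(Cl)cc2)c(-c2ccc(Cl)cc2)c1C(=O)NC1CCC1`: 24800 nM
Compound 3 `CCN(CC)CCNC(=O)Nc1sc(-c2ccc(Cl)cc2)c(-c2ccc(Cl)cc2)c1C(=O)NC1CC1`: "not determined" (no result reported)

Compound 1 holds the lower of the two numbers available, and compound 3 offers no number for comparison. The next compound to be measured is compound 4 `CC(C)CNC(=O)c1c(N)sc(-c2ccc(Cl)cc2)c1-c1ccc(Cl)cc1`, which keeps the core of compound 1 and changes one group: isobutylamino in place of 4-methylpiperidin-1-yl on a carbonyl carbon. In words, isobutylamino stands in place of 4-methylpiperidin-1-yl on a carbonyl carbon.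

Within the data shown here, one measured step bears on this change: a 4.3-fold higher number from compound 1 to compound 2 (0.63 log units; beyond the scatter). It is modest but beyond the scatter, and it removes the same 4-methylpiperidin-1-yl from the same carbonyl carbon, with cyclobutylamino entering instead. The entering group in compound 4 has no ring, so this single step is only an approximate guide. It gives the direction, and a step of similar or somewhat smaller size toward a higher number is expected in this assay. The expected change is a 2.6-fold higher number from compound 1 to compound 4 (0.42 log units; beyond the scatter). For compound 4, the estimated value is 15000 nM, with an expected range of 5000 nM to 40000 nM.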

Compound 4, half-maximal inhibitory concentration: 13200 nM
For compound 4 the middle estimate is 1.1-fold (0.06 log units) above the measured one; measured number inside the range.
By their numbers in this assay, from the lowest: compound 1; then compounds 4 and 2 (each within the scatter of the next).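

On the carbonyl carbon, isobutylamino in place of 4-methylpiperidin-1-yl gives a 2.3-fold higher number from compound 1 to compound 4 (0.36 log units; beyond the scatter) in this assay, so the rise seen with cyclobutylamino, a 4.3-fold higher number from compound 1 to compound 2 (0.63 log units; beyond the scatter), also appears with an entering group that has no ring. Isobutyl in place of cyclobutyl on the amide-type nitrogen gives a 1.9-fold lower number from compound 2 to compound 4 (0.27 log units; within the scatter), which does not separate the two groups, so a ring on that nitrogen makes no readable difference between this pair. Among these compounds, compound 1, the only measured compound without the amide hydrogen, holds the lowest number, but the amide hydrogen, the ring and the size of the group all change together in both steps away from it, so these compounds cannot assign the rise to any one of them.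

Open, on these data alone, is how a piperidin-1-yl without the methyl, a morpholin-4-yl or a longer chain ending in a diethylamino group would read on the same carbonyl carbon. No measurement at hand accounts for the size of either step.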